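Lengthening the Chain of Compound 1

A few compounds are considered here, and "the series" means these few. Any claim that something is new, unique, unknown or untested is made for them only; others in the source may bear on it.

In a functional assay on SW480 cells (Homo sapiens) for antiproliferative activity, read by MTT assay, with a stated time of 48 h (a lower number here means a stronger inhibitor, a higher number a weaker inhibitor), compound 1 (`CCCCCCC(CCO)n1cnc2c(Cl)ncnc21`) gives 16700 nM and compound 3 (`C=C(CO)C(CCCCCC)n1cnc2c(Cl)ncnc21`) gives 32000 nM as two values within the scatter of each other. For compound 2 (`CCCCCCC(CCO)n1cnc2c(N(C)C)ncnc21`) the result is a limit (> 50000 nM). Compound 4 (`CCCCCCCCC(CCO)n1cnc2c(Cl)ncnc21`) has ethyl in place of hydrogen on a saturated chain carbon, seven bonds along the chain from an aromatic nitrogen. Two measured steps start from compound 1 (an at least 2.9-fold higher number from compound 1 to compound 2 (0.47 log units; beyond the scatter); a 1.9-fold higher number from compound 1 to compound 3 (0.28 log units; within the scatter)), but neither alters this part of the chain and so neither gives a direct guide. No change beyond the scatter is therefore expected (a 1.2-fold lower number from compound 1 to compound 4 (0.08 log units; within the scatter)). Compound 4 is estimated at 14000 nM in this assay (expected range 6000 nM to 35000 nM).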

Compound 4, half-maximal inhibitory concentration: 1370 nM
For compound 4 the middle estimate is 10-fold (1.01 log units) above the measured one; the measured number lies below the stated range.
By their numbers in this assay, from the lowest: compound 4; then compounds 1 and 3 (each within the scatter of the next). At a limit, above all of these: compound 2.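

For the compounds shown here, the outer end of the chain, which none of the earlier steps touched, proves to be a sensitive place: in this assay the ethyl in place of hydrogen gives a 12-fold lower number from compound 1 to compound 4 (1.09 log units; beyond the scatter). With the chloro group and the 2-hydroxyethyl group unchanged, the added ethyl is the only difference, so chain length alone can move this number by a large step. Nothing shown here gives a cause for this step.

Still open, on these data alone, is whether a longer chain would lower the number further or reverse the gain. Also open, as far as these compounds go, is whether an amine or a carboxylic acid at the chain end would keep it.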